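The source may hold more compounds than are shown below. What is called first, only, known or untested is meant among the compounds shown, and "the series" means these compounds.

Measured so far:

Compound 1, `CCc1nnc2c(C#N)c(N3CCC(c4ccccc4)CC3)ccn12`: 696 nM
Compound 2, `N#Cc1c(N2CCC(c3ccccc3)CC2)ccn2c(CC3CC3)nnc12`: 74 nM
Compound 3, `COCc1nnc2c(C#N)c(N3CCC(c4ccccc4)CC3)ccn12`: 468 nM

All three share one core and differ only in the group on the saturated chain carbon bound to an aromatic carbon. In a functional assay on CHO cells for positive allosteric modulation of metabotropic glutamate receptor 2 (Homo sapiens), read by GTPgammaS binding, with a stated time of 30 min (on this read-out lower numbers stand for an effect already at smaller amounts and higher numbers for an effect only at larger amounts of compound), compound 2 gives the lowest number of the three: a 9.4-fold lower number from compound 1 to compound 2 (0.97 log units; beyond the scatter), and a 6.3-fold higher number from compound 2 to compound 3 (0.80 log units; beyond the scatter), both beyond the scatter, while a 1.5-fold lower number from compound 1 to compound 3 (0.17 log units; within the scatter) stays within it.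

Compound 4, `Clc1c(N2CCC(c3ccccc3)CC2)ccn2c(CC3CC3)nnc12`, keeps the cyclopropyl chain of compound 2 and changes a different position: chloro in place of cyano on an aromatic carbon. Within the data shown here, none of the measured steps touches this position; all of them vary the chain, so they say nothing direct about swapping cyano for chloro. With no guidance, the expected step of a 1.8-fold higher number from compound 2 to compound 4 (0.24 log units; within the scatter) is set near none beyond the scatter, with the direction left open. Compound 4 is therefore estimated at 130 nM in this assay, with a range from 30 nM to 600 nM.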

Compound 4, half-maximal effective concentration: 102 nM
Compound 4: middle estimate off by 1.3-fold (0.11 log units), on the high side; low and high end bracket the measured number.
By their numbers in this assay, from the lowest: compounds 2 and 4 (each within the scatter of the next); then compounds 3 and 1 (each within the scatter of the next).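

In this assay, chloro in place of cyano on this aromatic carbon gives a 1.4-fold higher number from compound 2 to compound 4 (0.14 log units; within the scatter), so the two groups cannot be told apart on this read-out. Among these compounds, the earlier compounds varied only the chain, which makes this the first reading at this position: with the cyclopropyl chain in place, the cyano group is not needed for a number in the range of compound 2, and a single chlorine atom, with no hydrogen-bond acceptor counted, does as well. Nothing measured here explains why the two groups read alike.

Going by these compounds, whether the same swap would read alike with the ethyl or methoxymethyl chains of compound 1 and compound 3 remains open. Also open, on these data alone, is how this position would respond to quite different groups, such as an amine, a methyl group or a trifluoromethyl group.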